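The source may report more compounds than this note shows. Statements on the series, on what has been measured and on what is new or still open speak of the compounds shown alone.

Measured in an assay on membranes from brain for displacement of a labelled ligand from Sigma non-opioid intracellular receptor 1 (Cavia porcellus), read by scintillation counting, with a stated time of 120 min; on this read-out lower numbers stand for stronger inhibition and higher numbers for weaker inhibition:
compound 1 `COC1Cc2sc(-c3ccc(-c4ccccc4)cc3)cc2C2(CCN(Cc3ccccc3)CC2)O1` gives 220 nM
compound 2 `c1ccc(CN2CCC3(CC2)OCCc2cc(-c4ccccc4)sc23)cc1` gives 2.4 nM
compound 3 `COC1Cc2cc(-c3ccccc3)sc2C2(CCN(Cc3ccccc3)CC2)O1` gives 16 nM

Compound 3 stands second of the three numbers in this assay; compound 2 lies nearer to it, compound 1 further away. Within the data shown here, the one single-point step in the set, a 6.7-fold higher number from compound 2 to compound 3 (0.82 log units; beyond the scatter), concerns a methoxy in place of hydrogen on a saturated ring carbon and leaves the aryl group untouched. Compound 4 `COC1Cc2cc(-c3cccnc3)sc2C2(CCN(Cc3ccccc3)CC2)O1` differs from compound 3 in that (pyridin-3-yl in place of phenyl on an aromatic carbon). Among the measured compounds shown here, no measured pair shows this aryl ring exchanged for a heteroaryl ring; compounds 1 and 2 vary at other places, so the size of the step has no direct reference in the data. With only the methoxy step known, the step in this assay is expected to be small, leaning toward a higher number: a 1.9-fold higher number from compound 3 to compound 4 (0.27 log units; within the scatter). Compound 4 is therefore estimated at 30 nM in this assay, with a range from 8 nM to 120 nM.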

Compound 4, inhibition constant: 2.5 nM
The estimate for compound 4 lay 12-fold (1.08 log units) above the measured number, outside the stated range (below it).
By their numbers in this assay, from the lowest: compounds 2 and 4 (each within the scatter of the next); then compound 3; then compound 1.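

In this assay, the aromatic carbon next to the ring sulfur proves sensitive to the aryl ring it carries: pyridin-3-yl in place of phenyl gives a 6.4-fold lower number from compound 3 to compound 4 (0.81 log units; beyond the scatter) in the methoxy series. The exchange keeps the count of 6 heavy atoms and no net charge, so one ring carbon replaced by nitrogen, with 1 hydrogen-bond acceptor entering, is enough to move the number beyond the scatter. Among these compounds, this is the first step read at this position, and no measurement at hand bears on the reason for it.

From the compounds shown here alone, it remains open whether pyridin-4-yl or pyrimidin-5-yl on this carbon gives a step of similar size. The same exchange on the core of compound 2, with hydrogen in place of methoxy, also remains to be read.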